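Losing the benzyl group from compound 2

The source may report more compounds than this note shows. Statements on the series, on what has been measured and on what is new or still open speak of the compounds shown alone.

In an assay on nucleic acid for binding affinity to Nucleic Acid, read by FRET, tested at 3 uM (on this read-out higher numbers stand for stronger stabilisation of the target against heat and lower numbers for weaker stabilisation of the target), compound 1 (`CCOC(=O)c1ccc(-c2csc3nc(-c4ccc(OCc5ccccc5)cc4)nn23)cc1`) gives < 1 degrees C, which is a limit of the assay. Compound 2 (`O=C(NCCN1CCCCC1)c1ccc(-c2csc3nc(-c4ccc(OCc5ccccc5)cc4)nn23)cc1`) gives < 1 degrees C, also a limit and not a number. Compound 2 thus stands at the limit of < 1 degrees C in this assay, at which 2 of the 2 values shown sit. Compound 3 (`O=C(NCCN1CCCCC1)c1ccc(-c2csc3nc(-c4ccc(O)cc4)nn23)cc1`) follows from compound 2 by hydrogen in place of benzyl on an oxygen on an aromatic ring, that is, benzyloxy to hydroxy. For the measured compounds named here, the only measured step is a step that the two limits leave unreadable from compound 1 to compound 2, a different change, so it sets no size here. The expected step is a step that the limit leaves unreadable from compound 2 to compound 3, and nothing beyond the scatter is expected in this assay. Compound 3 is estimated at 0.7 degrees C, with an expected range of 0 degrees C to 3 degrees C.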

Compound 3, shift of the target's melting temperature: < 1 degrees C
Compound 3 ended at the assay's limit (the forecaster's own chance of this, stated with the estimate: 70%); the middle value lies beyond the limit too.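

No new step can be read between compound 2 and compound 3, because both sit at a limit: the limit of < 1 degrees C in this assay, at which 3 of the 3 values shown sit.

The compounds shown leave open what effect, if any, losing the benzyl group has in this assay.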